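The source may report more compounds than this note shows. Statements on the series, on what has been measured and on what is new or still open speak of the compounds shown alone.

Three compounds have been measured so far in a functional assay on HepG2 cells (Homo sapiens) for inhibition, read by MTT assay, with a stated time of 120 h (on this read-out higher numbers stand for weaker inhibition and lower numbers for stronger inhibition), and give these values:

- compound 1 `O=C(/C=C/c1ccc(NC(=O)Nc2ccc(Cl)c(C(F)(F)F)c2)cc1)NC1CCC1` at 7510 nM
- compound 2 `CC(NC(=O)/C=C/c1ccc(NC(=O)Nc2ccc(Cl)c(C(F)(F)F)c2)cc1)c1ccccc1` at 12200 nM
- compound 3 `CC(NC(=O)c1ccc(-c2ccc(NC(=O)Nc3cc(C(F)(F)F)ccc3Cl)cc2)cc1)c1ccccc1` at 18400 nM

Compound 1 sits level with compound 2 within the scatter, while compound 3 shows a clearly higher number than compound 1. Compound 4 `CNC(=O)CCc1ccc(NC(=O)Nc2ccc(Cl)c(C(F)(F)F)c2)cc1` has not been measured yet. Its difference from compound 1 is 2-(methylcarbamoyl)ethyl in place of 2-(cyclobutylcarbamoyl)ethenyl on an aromatic carbon on an aromatic carbon para to a large group. In plain terms, the cyclobutyl gives way to a methyl and the ethenyl link becomes an ethyl link.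

Going by the values given here, only one measured step changes a single place, namely a 1.6-fold higher number from compound 1 to compound 2 (0.21 log units; within the scatter) for 1-phenylethyl in place of cyclobutyl on an amide-type nitrogen. That step suggests the swap on this nitrogen may matter little, although methyl was not tested there. Among the compounds with values here, no measured step covers the loss of the ethenyl double bond. Compound 3 at 18400 nM differs from compound 1 in more than one place and is only a loose guide, but it shows that higher numbers occur in this set. A small rise is therefore expected, one that may not clear the scatter. The expected change is a 1.6-fold higher number from compound 1 to compound 4 (0.20 log units; within the scatter) in this estimate. The estimate for compound 4 is 12000 nM within an expected range of 5000 nM to 30000 nM in this read-out.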

Compound 4, half-maximal inhibitory concentration: 21000 nM
Compound 4: middle estimate off by 1.8-fold (0.24 log units), on the low side; low and high end bracket the measured number.
By their numbers in this assay, from the lowest: compounds 1, 2, 3 and 4 (each within the scatter of the next, the first and the last beyond it).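

In this assay, replacing 2-(cyclobutylcarbamoyl)ethenyl with 2-(methylcarbamoyl)ethyl on the aromatic carbon gives a 2.8-fold higher number from compound 1 to compound 4 (0.45 log units; beyond the scatter). Going by these compounds alone, this shows that inhibition responds to a change at this place on the shared core, whereas the one earlier single-place step, a 1.6-fold higher number from compound 1 to compound 2 (0.21 log units; within the scatter), stayed within the scatter. The new step alters the group on the amide nitrogen and the link to the ring together, so it cannot show which alteration accounts for the weaker inhibition, and no supporting data explain the rise.

The two alterations could be separated by a pair of compounds, one keeping the ethenyl link with a methyl on the amide nitrogen and the other carrying the ethyl link with a cyclobutyl there. As far as these compounds go, it also remains open how this assay would respond if the amide were replaced by a carboxylic acid or an amine, or if the link to the ring were a longer chain.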